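Nitro in place of hydroxy on the bridging aromatic ring

The source may hold more compounds than are shown below. What is called first, only, known or untested is meant among the compounds shown, and "the series" means these compounds.

Measured so far in a functional assay on P388 cells (Mus musculus) for cytotoxicity; on this read-out lower numbers stand for stronger inhibition and higher numbers for weaker inhibition:
compound 1 `COc1ccc(C[C@H]2C(=O)N[C@@H](C)C(=O)N(C)[C@H]3Cc4ccc(cc4)Oc4cc(cc([N+](=O)[O-])c4O)C[C@@H](C(=O)N[C@H](C)C(=O)N[C@@H](C)C(=O)N2C)N(C)C3=O)cc1` gives 0.014 ug/mL
compound 2 `COc1ccc(C[C@H]2C(=O)N[C@@H](C)C(=O)N(C)[C@H]3Cc4ccc(cc4)Oc4cc(cc([N+](=O)[O-])c4OC)C[C@@H](C(=O)N[C@H](C)C(=O)N[C@@H](C)C(=O)N2C)N(C)C3=O)cc1` gives 0.01 ug/mL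
compound 3 `COc1ccc(C[C@H]2C(=O)N[C@@H](C)C(=O)N(C)[C@H]3Cc4ccc(cc4)Oc4cc(c(O)cc4OC)C[C@@H](C(=O)N[C@H](C)C(=O)N[C@@H](C)C(=O)N2C)N(C)C3=O)cc1` gives 0.093 ug/mL

Compound 3 stands highest of the three numbers in this assay; compound 1 is the nearest and compound 2 the furthest, both gaps beyond the scatter. Going by the values given here, the one step between measured compounds, a 1.4-fold lower number from compound 1 to compound 2 (0.15 log units; within the scatter), lies within the scatter and concerns a methyl in place of hydrogen on an oxygen, not the change at hand.

Compound 4 `COc1ccc(C[C@H]2C(=O)N[C@@H](C)C(=O)N(C)[C@H]3Cc4ccc(cc4)Oc4cc(c([N+](=O)[O-])cc4OC)C[C@@H](C(=O)N[C@H](C)C(=O)N[C@@H](C)C(=O)N2C)N(C)C3=O)cc1` differs from compound 3 as follows: nitro in place of hydroxy on an aromatic carbon. Among the compounds with values here, no measured step covers a nitro in place of hydroxy directly. What the numbers do show is that both compounds carrying a nitro, compound 1 with 0.014 ug/mL and compound 2 with 0.01 ug/mL, sit well below compound 3, which lacks one. Within the data shown here, on that basis a step toward a lower number is expected for compound 4 in this assay, of the size a 3.1-fold lower number from compound 3 to compound 4 (0.49 log units; beyond the scatter), though with a wide range since the change is read from only two nitro-bearing compounds. Compound 4 is estimated at 0.03 ug/mL, between 0.01 ug/mL and 0.1 ug/mL.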

Compound 4, half-maximal inhibitory concentration: 0.056 ug/mL
Estimate against measurement, compound 4: 1.9-fold (0.27 log units) below; low and high end bracket the measured number.
By their numbers in this assay, from the lowest: compounds 2 and 1 (each within the scatter of the next); then compounds 4 and 3 (each within the scatter of the next).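

In this assay, the direct exchange of hydroxy for nitro on this aromatic carbon, meta to a methoxy group and para to a fused ring, gives a 1.7-fold lower number from compound 3 to compound 4 (0.22 log units; within the scatter), so this single change does not separate the two compounds beyond the scatter. Compound 1 and compound 2 each differ from compound 3 in more than one place and could not isolate this exchange, whereas this pair does, and it shows that the hydrogen-bond donor of the hydroxy can give way here to a nitro with 0 hydrogen-bond donors without a step beyond the scatter. No measurement at hand offers a reason for this result.

On these data alone, only hydroxy and nitro are compared on this aromatic carbon, so whether an amine, a carboxylic acid or a methoxy group there would give a step beyond the scatter remains open. Also open, as far as these compounds go, is whether the same exchange would stay within the scatter on the core of compound 1, where the nitro stands at another place on the ring.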